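A few compounds are considered here, and "the series" means these few. Any claim that something is new, unique, unknown or untested is made for them only; others in the source may bear on it.

Compound 1 `COc1cccc(N2CCN(C(=O)C(C)N3C(=O)CCC3=O)CC2)c1`: 0%
Compound 2 `CC(C(=O)N1CCN(c2ccc(F)cc2)CC1)N1C(=O)CCC1=O`: 0%
Compound 3 `CCC(C(=O)N1CCN(c2cccc(Cl)c2)CC1)N1C(=O)CCC1=O`: 0%

In a functional assay on the whole organism (strain Swiss) with Mus musculus as the target, in the maximal electroshock model, with a stated time of 2 h, at a dose of 100 mg/kg by the intraperitoneal route (on this read-out lower numbers stand for a weaker effect and higher numbers for a stronger effect at the one dose given), compound 1 stands level with compounds 2 and 3 at the digits reported. Its nearest neighbour is compound 2, reached by no change at the digits printed from compound 1 to compound 2 (within the scatter). Among the compounds with values here, compound 3 shows the same value as compound 1, and no single-point step links the two.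

Compound 4 `Cc1cccc(N2CCN(C(=O)C(C)N3C(=O)CCC3=O)CC2)c1` differs from compound 1 by methyl in place of methoxy on an aromatic carbon. Within the data shown here, the one measured step that bears on this change is no change at the digits printed from compound 1 to compound 2 (within the scatter), which likewise altered the group on the aromatic ring and moved nothing beyond the scatter. On that basis compound 4 is expected to show no step beyond the scatter, no change at the digits printed from compound 1 to compound 4 (within the scatter). Compound 4 is therefore estimated at 0%, with a range from 0% to 15%.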

Compound 4, a percentage reported as activity, at one dose (the size of the read-out at that dose, not a potency): 0%
For compound 4 middle estimate and measured number coincide at the digits printed; low and high end bracket the measured number.
By their numbers in this assay, from the lowest: compounds 1, 2, 3 and 4 (each within the scatter of the next).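

Methyl in place of methoxy on the aromatic carbon, which removes a hydrogen-bond acceptor from this position, gives no change at the digits printed from compound 1 to compound 4 (within the scatter) in this assay. Changing the aromatic group at a different position and in a different way also leaves the read-out unmoved, with no change at the digits printed from compound 2 to compound 4 (within the scatter), and compound 4 gives 0%. No measurement here speaks to why these changes leave the read-out unmoved. On these data alone, whether an amine or a carboxylic acid on the aromatic ring would give any effect at this dose stays open. So does the effect of a longer chain there.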